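A few compounds are considered here, and "the series" means these few. Any claim that something is new, unique, unknown or untested is made for them only; others in the source may bear on it.

Working notes, measured in a functional assay on HL-60 cells (Homo sapiens) for inhibition, read by CCK-8 assay, with a stated time of 48 h, tested at 20 uM; a higher number here means more inhibition of growth at the concentration tested, a lower number less inhibition of growth:

- compound 1 `COc1ccc(S(=O)(=O)Oc2ccccc2/C=C(\C#N)C(=O)Nc2nnc(Cc3cccc4ccccc34)s2)cc1`: 98%
- compound 2 `N#C/C(=C\c1ccccc1OS(=O)(=O)c1ccc([N+](=O)[O-])cc1)C(=O)Nc1nnc(Cc2cccc3ccccc23)s1`: 18%
- compound 3 `N#C/C(=C\c1ccccc1OS(=O)(=O)c1ccccc1[N+](=O)[O-])C(=O)Nc1nnc(Cc2cccc3ccccc23)s1`: 23%

Compound 3 sits in the low pair of the series. The data show a number 5 percentage points higher from compound 2 to compound 3 (within the scatter), and also a number 75 percentage points lower from compound 1 to compound 3 (beyond the scatter).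

The next structure is compound 4 `Cc1ccc(Cc2nnc(NC(=O)/C(C#N)=C/c3ccccc3OS(=O)(=O)c3ccccc3[N+](=O)[O-])s2)cc1`, which keeps the 2-nitrophenyl on the sulfonyl sulfur. Its difference is 4-methylphenyl in place of naphthalen-1-yl on a saturated chain carbon bound to an aromatic carbon.

Going by the values given here, no measured step touches this place. All three steps change the group on the sulfonyl sulfur, and the largest is a number 80 percentage points lower from compound 1 to compound 2 (beyond the scatter). That shows how far the series can move, but only at the other end of the molecule. The closest reference is therefore compound 3 at 23%, and no change beyond the scatter is expected in this assay, though with little confidence. The expected step is a number 1 percentage points lower from compound 3 to compound 4 (within the scatter). Compound 4 is estimated at 22%, with an expected range of 6% to 55%.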

Compound 4, percent growth inhibition at one concentration: 33%
For compound 4 the middle estimate is 11 percentage points below the measured one, and the stated range covers the measured number.
By their numbers in this assay, from the lowest: compounds 2, 3 and 4 (each within the scatter of the next, the first and the last beyond it); then compound 1.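

In this assay, going by these compounds alone, the change from naphthalen-1-yl to 4-methylphenyl on a saturated chain carbon bound to an aromatic carbon gives a number 10 percentage points higher from compound 3 to compound 4 (within the scatter), the first reading at this end of the molecule. With 2-nitrophenyl kept on the sulfonyl sulfur, replacing two six-membered aromatic rings of carbon only with one leaves the result within the scatter, unlike the large steps printed for the change from 4-methoxyphenyl to either nitrophenyl group on that sulfur. No measurement given here bears on the reason for this result.

This step is shown only with 2-nitrophenyl on the sulfonyl sulfur, so its size alongside the 4-methoxyphenyl of compound 1, at 98%, remains open. Also open, from the compounds shown here alone, is how an amine, a carboxylic acid or a longer chain would read in place of 4-methylphenyl on the same carbon.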